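Halogen swap on the benzylsulfanyl arm, second instance

This account rests on a few compounds, and the source may have more. Where it says the series, first, only, none or still open, it means among the compounds named here.

All numbers here come from a functional assay on the whole organism (artery, strain albino) with Rattus norvegicus as the target, with a stated time of 180 min, at a dose of 10 mg/kg by the oral route; a lower number here means less inhibition, a higher number more inhibition at the dose given (going by the name of the read-out).

compound 1 `CC1=C(C(=O)Nc2ccc(F)cc2)C(c2ccc([N+](=O)[O-])cc2)N=C(SCc2ccc(Cl)cc2)N1`: 23.2%
compound 2 `CC1=C(C(=O)Nc2ccc(F)cc2)C(c2ccc([N+](=O)[O-])cc2)N=C(SCc2ccc(F)cc2)N1`: 20.1%
compound 3 `CC1=C(C(=O)Nc2ccc(Br)cc2)C(c2ccc(Cl)cc2Cl)N=C(SCc2ccc(Cl)cc2)N1`: 23.2%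

Compound 2 differs from compound 1 by fluoro in place of chloro on an aromatic carbon, and the measured step is a number 3.1 percentage points lower from compound 1 to compound 2 (within the scatter). Compound 3 carries a different core; how its core differs from that of compound 1 is not broken down here. Its value sits level with that of compound 1 at the digits reported, and the two together are the highest of the three numbers, with compound 2 within the scatter of both.

Compound 4 `CC1=C(C(=O)Nc2ccc(Br)cc2)C(c2ccc(Cl)cc2Cl)N=C(SCc2ccc(F)cc2)N1` is not yet measured. It differs from compound 3 by fluoro in place of chloro on an aromatic carbon, the same change as between compound 1 and compound 2, at the same place on the ring. The step from compound 3 to compound 4 in this assay is expected to be a number 3.2 percentage points lower from compound 3 to compound 4 (within the scatter), a size resting on the earlier step of a number 3.1 percentage points lower from compound 1 to compound 2 (within the scatter) and on the starting point of compound 3 at 23.2%. Compound 4 is accordingly estimated at 20%, with an expected range from 9% to 31%.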

Compound 4, a percentage reported as inhibition, in the whole organism at one dose (the size of the read-out at that dose, not a potency): 28.4%
Estimate against measurement, compound 4: 8.4 percentage points below; low and high end bracket the measured number.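

Fluoro in place of chloro, (4-fluorobenzyl)sulfanyl for (4-chlorobenzyl)sulfanyl, gives a number 5.2 percentage points higher from compound 3 to compound 4 (within the scatter) on the core of compound 3 in this assay after oral dosing. Neither this step nor the earlier one stands clear of the scatter, so their opposite signs carry no weight: the pair shows no dependence on the core, but it also shows no effect of the change on either core. Carrying the change across these two cores therefore leaves the read-out unchanged as far as the data can tell, and the comparison reads: the same change on two cores in this assay, a number 3.1 percentage points lower (within the scatter) from compound 1 to compound 2 and a number 5.2 percentage points higher (within the scatter) from compound 3 to compound 4, 8.3 percentage points apart, within the scatter of two such steps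

The compounds shown carry only chloro or fluoro on the benzyl ring, so an unsubstituted benzyl, a methoxy or trifluoromethyl group at that place, or an amine or carboxylic acid on the arm remains open. All the numbers come from a single dose and time, which leaves open how the compounds would compare across a range of doses.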